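Chloromethylbenzyl Purine Analogues: Growth Inhibition Notes

A few compounds are considered here, and "the series" means these few. Any claim that something is new, unique, unknown or untested is made for them only; others in the source may bear on it.

Measured so far:
- compound 1 `Nc1nc(Cl)c2ncn(Cc3ccccc3CCl)c2n1`: 8130 nM
- compound 2 `ClCc1ccc(Cn2cnc3c(Cl)nc(Cl)nc32)cc1`: 15900 nM
- compound 3 `ClCc1ccccc1Cn1cnc2ncnc(Cl)c21`: 2450 nM

In a functional assay on BT-549 cells (Homo sapiens) for cytotoxicity, read by sulforhodamine B assay, with a stated time of 48 h (a lower number here means a stronger inhibitor of growth, a higher number a weaker inhibitor of growth), compound 1 gives 8130 nM, the second highest of the three numbers. Compound 2 sits within the scatter of compound 1, so no order can be read between them; compound 3 lies beyond the scatter, at a lower number than compound 1.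

Compound 4 `ClCc1ccccc1Cn1cnc2c(Cl)ncnc21` is the next step from compound 1. The change is hydrogen in place of amino on an aromatic carbon. Within the data shown here, no measured pair yet shows this change, so its size is an open question. Given that compound 3 gives 2450 nM with no amino group on its core, a modest step toward a lower number is expected, possibly within the scatter. For compound 4 the estimated value is 4500 nM (range 1500 nM to 13000 nM), which means an expected step of a 1.8-fold lower number from compound 1 to compound 4 (0.26 log units; within the scatter).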

Compound 4, concentration for 50% growth inhibition: 1990 nM
For compound 4 the middle estimate is 2.3-fold (0.35 log units) above the measured one; the measured number falls inside the stated range.
By their numbers in this assay, from the lowest: compounds 4 and 3 (each within the scatter of the next); then compounds 1 and 2 (each within the scatter of the next).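

In this assay, hydrogen in place of amino on the aromatic carbon between two ring nitrogen atoms gives a 4.1-fold lower number from compound 1 to compound 4 (0.61 log units; beyond the scatter), the first one-place change available in the series. The amino group at this position is therefore not required for growth inhibition in this pair, and its removal goes with a stronger inhibitor. Nothing on hand accounts for the step.

Going by these compounds, whether a methyl group, a hydroxyl group or a dimethylamino group at this position would match hydrogen remains open. A single pair also cannot show whether the step carries over to other substitution on the shared core.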